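A few compounds are considered here, and "the series" means these few. Any claim that something is new, unique, unknown or untested is made for them only; others in the source may bear on it.

Working notes on the series.

Of the compounds shown here, two have been measured. Compound 1 `C=Cc1cccc(C(=O)NCN2CCC(c3cccc[n+]3[O-])CC2)c1` and compound 2 `CCOc1cccc(C(=O)NCN2CCC(c3cccc[n+]3[O-])CC2)c1` share the same core and differ only on one aromatic carbon of the phenyl group attached to the carbonyl. In a functional assay on HEK293 cells for agonist activity at D(4) dopamine receptor (Homo sapiens), read by FLIPR (on this read-out higher numbers stand for larger maximal responses and lower numbers for smaller maximal responses), compound 1 gives 63% and compound 2 gives 54%; the step of a number 9 percentage points lower from compound 1 to compound 2 (within the scatter) lies within the scatter, so the two cannot be ordered. Compound 1 has the higher of the two numbers, with compound 2 nearest, within the scatter.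

Compound 3 `Cc1cc(C(=O)NCN2CCC(c3cccc[n+]3[O-])CC2)ccc1Cl` is not yet measured. Relative to compound 1 the change is 4-chloro-3-methylphenyl in place of 3-vinylphenyl on a carbonyl carbon. Going by the values given here, only one measured step exists, from compound 1 to compound 2, and it swapped a single substituent on the same phenyl group without a change beyond the scatter, a number 9 percentage points lower from compound 1 to compound 2 (within the scatter). Compound 3 replaces the whole substituted phenyl rather than one group, so that step bears on it only loosely. With no contrary evidence, no step beyond the scatter is expected in this assay. For compound 3 the estimated step is a number 3 percentage points lower from compound 1 to compound 3 (within the scatter), with an expected value of 60% in a range from 40% to 80%.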

Compound 3, largest response reached (reported as efficacy), in percent of the reference or control that the assay uses: 62%
The estimate for compound 3 lay 2 percentage points below the measured number; the range from low to high includes it.
By their numbers in this assay, from the lowest: compounds 2, 3 and 1 (each within the scatter of the next).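

The exchange of 3-vinylphenyl for 4-chloro-3-methylphenyl on a carbonyl carbon gives, in this assay, a number 1 percentage points lower from compound 1 to compound 3 (within the scatter), so this step, unlike the earlier one, changes the whole substituted phenyl and still stays inside the scatter. The entering group has no double bond outside the aromatic ring and brings a chlorine, yet compound 3 reads 62%, so within this pair the vinyl double bond is not needed for a maximal response of this size. No measured information bears on why the two groups read alike, and the result shows only that the response is retained, not what underlies it.

On these data alone, both groups in this pair hold the same number of heavy atoms and neither carries a hydrogen-bond donor or acceptor, so it stays open whether the maximal response would hold with an amine or a carboxylic acid on the phenyl. Also open, as far as these compounds go, is whether a naphthyl group or a longer alkyl chain could stand in place of the phenyl on the carbonyl carbon, and whether any change elsewhere on the shared core would move the read-out beyond the scatter.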